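Fluorine Added to the Aryl Amide of Compound 3

The compounds below may be only part of what the source reports. "The series", "measured", "known", "first", "only" and "open" are said of these compounds alone.

In an assay on isolated protein for binding affinity to melanin-concentrating hormone receptor 1 (Homo sapiens) (on this read-out lower numbers stand for stronger inhibition and higher numbers for weaker inhibition), compound 1 `COc1ccc(C(=O)NC2CCN(Cc3ccc4ccccc4c3)CC2)cc1OC` gives 1000 nM, compound 2 `COc1cc(OC)cc(C(=O)N(C)C2CCN(Cc3ccc4ccccc4c3)CC2)c1` gives 169 nM, and compound 3 `COc1cccc(C(=O)N[C@@H]2CCN(Cc3ccc4ccccc4c3)C2)c1` gives 67 nM. Compound 3 holds the lowest number of the three; its gap to compound 2 is beyond the scatter, and its gap to compound 1 is wider still. Compound 4 `COc1cc(C(=O)N[C@@H]2CCN(Cc3ccc4ccccc4c3)C2)ccc1F` is built from compound 3 by fluoro in place of hydrogen on an aromatic carbon. For the measured compounds named here, no two measured compounds differ in a single place, so no comparable step is available to guide the expectation. The change is small, and the step of a 1.2-fold lower number from compound 3 to compound 4 (0.09 log units; within the scatter) is expected to stay within the usual scatter, with no clear direction. Compound 4 is therefore estimated at 55 nM, with a range from 20 nM to 160 nM.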

Compound 4, inhibition constant: 62 nM
Beside the measured number, compound 4's estimate is 1.1-fold (0.05 log units) below it; the range from low to high includes it.
By their numbers in this assay, from the lowest: compounds 4 and 3 (each within the scatter of the next); then compound 2; then compound 1.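

In this assay, for the compounds shown here, a 1.1-fold lower number from compound 3 to compound 4 (0.03 log units; within the scatter) gives the first comparison of compounds that differ in one place. It shows that on the 3-methoxyphenyl group, fluoro can replace hydrogen ortho to a methoxy group and para to a large group with no change beyond the scatter. Nothing measured here explains this result. From the compounds shown here alone, whether this position would read the same with a group larger than a single fluorine atom, such as a chloro group, a methoxy group or an amine, stays open. So does the effect of fluoro elsewhere on this ring.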